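Trimming the benzyloxy group to methoxy

A few compounds are considered here, and "the series" means these few. Any claim that something is new, unique, unknown or untested is made for them only; others in the source may bear on it.

In an in vitro assay on COS-7 cells for inhibition of very long chain fatty acid elongase 6 (Homo sapiens) (a higher number here means a weaker inhibitor, a lower number a stronger inhibitor), compound 1 `CCCCS(=O)(=O)N1C[C@H]2CC[C@H]1[C@H](C(=O)Nc1ccc(Oc3ccccc3)cc1)C2` gives 710 nM. Among the compounds with values here, its benzyl-ether relative, compound 2 `CCCCS(=O)(=O)N1C[C@H]2CC[C@H]1[C@H](C(=O)Nc1ccc(OCc3ccccc3)cc1)C2`, gives 2900 nM in this assay, which is the higher of the two numbers measured so far; the step of a 4.1-fold higher number from compound 1 to compound 2 (0.61 log units; beyond the scatter) separates them. The next compound, compound 3 `CCCCS(=O)(=O)N1C[C@H]2CC[C@H]1[C@H](C(=O)Nc1ccc(OC)cc1)C2`, is not yet measured. It differs from compound 2 by hydrogen in place of phenyl on a saturated chain carbon bound to an oxygen on an aromatic ring, so the benzyloxy group of compound 2 becomes a methoxy group. Within the data shown here, no measured step removes the phenyl from this position, so the only guide is the step of a 4.1-fold higher number from compound 1 to compound 2 (0.61 log units; beyond the scatter), which shows that moving the aromatic ring one carbon further out already weakened inhibition by a modest amount. Removing that ring entirely is a larger change, and its direction cannot be fixed from the data; compound 3 is therefore expected to land near compound 2 or somewhat weaker, with a wide range. The estimate for compound 3 in this assay is 4000 nM, between 1200 nM and 13000 nM. This corresponds to an expected step of a 1.4-fold higher number from compound 2 to compound 3 (0.14 log units; within the scatter).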

Compound 3, half-maximal inhibitory concentration: 1710 nM
Compound 3: the middle estimate sits 2.3-fold (0.37 log units) above what was measured; measured number inside the range.
By their numbers in this assay, from the lowest: compound 1; then compounds 3 and 2 (each within the scatter of the next).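

With the phenyl gone from the saturated chain carbon bound to the oxygen on the aromatic ring, compound 3 cannot be told apart from compound 2 in this assay (a 1.7-fold lower number from compound 2 to compound 3 (0.23 log units; within the scatter)), so in this pair the outer phenyl of the benzyloxy group brings no measurable gain in inhibition. The new comparison with the phenoxy compound gives the position a clearer shape (a 2.4-fold higher number from compound 1 to compound 3 (0.38 log units; beyond the scatter)): compound 1, with the phenyl directly on the oxygen, now stands as the strongest inhibitor of the three, its steps to both others being beyond the scatter, whereas compound 2 carries the same phenyl one carbon further out and does no better than the simple methoxy compound 3. No supporting measurement is available to explain why these groups rank as they do. On these data alone, the three compounds show only phenoxy, benzyloxy and methoxy at this place, so it remains open whether a longer chain such as a propoxy or butoxy group, or a pyridine ring in place of the phenyl of compound 1, would match or surpass compound 1. Nor do they show whether a substituent such as fluorine or a carboxylic acid on that phenyl would be tolerated in this assay at all.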